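The source may report more compounds than this note shows. Statements on the series, on what has been measured and on what is new or still open speak of the compounds shown alone.

Notes on the series. Compound 1 `COc1ccc(S(=O)(=O)Nc2ccc(-c3nc4ccccc4o3)cc2)cc1`, compound 2 `O=S(=O)(Nc1ccc(-c2nc3ccccc3o2)cc1)c1ccc(Cl)s1` and compound 3 `O=S(=O)(Nc1ccc(-c2nc3ccccc3o2)cc1)c1ccc(Cl)cc1` share one core and differ only in the group on the sulfonyl sulfur. In an assay on isolated protein for inhibition of malate dehydrogenase, mitochondrial (Sus scrofa), with stated times of 45 min and 30 min (on this read-out higher numbers stand for weaker inhibition and lower numbers for stronger inhibition), compound 1 gives only a limit, > 63000 nM. In this assay compound 2 likewise gives only a limit, > 63000 nM. In this assay compound 3 also gives only a limit, > 63000 nM. Compound 3 therefore stands exactly where every other value in the set stands: all three sit at the limit of > 63000 nM in this assay, at which 3 of the 3 values shown sit, so nothing separates the compounds on the numbers shown. The step that the two limits leave unreadable from compound 1 to compound 3 and the step that the two limits leave unreadable from compound 2 to compound 3 are both hidden by the limits, as is a step that the two limits leave unreadable from compound 1 to compound 2; none of them has a readable size.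

Compound 4 `Cc1ccc(S(=O)(=O)Nc2ccc(-c3nc4ccccc4o3)cc2)cc1` is the next member. It differs from compound 3 by methyl in place of chloro on an aromatic carbon. The measured steps that bear on this change, those leading into compound 3 from compound 1 and from compound 2, are all unreadable, so no size can be taken from them; what they do show is that three variations of the group on the sulfonyl sulfur all stayed at the limit. No step beyond the scatter is therefore expected in this assay, in either direction. Compound 4 is expected to remain at the limit as well, with an estimated value of 100000 nM, within 30000 nM to 400000 nM. The step that the limit leaves unreadable from compound 3 to compound 4 that this estimate means is expected to lie within the scatter.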

Compound 4, half-maximal inhibitory concentration: > 63000 nM
Compound 4 ended at the assay's limit; the forecaster's own chance of this, stated with the estimate: 85%; the middle value lies beyond the limit too.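

Among these compounds, compound 4 gives only a limit in this assay, > 63000 nM, so no step from compound 1, compound 2 or compound 3 to compound 4 can be read. The compounds shown leave open whether any group on the sulfonyl sulfur separates them in this assay, as all four stand at one limit: the limit of > 63000 nM in this assay, at which 4 of the 4 values shown sit.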